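Swapping the Pyridine Substituent on Compound 1

The source may report more compounds than this note shows. Statements on the series, on what has been measured and on what is new or still open speak of the compounds shown alone.

Compound 1 `O=C(O)Cc1sc(C(c2ccc(F)cc2)c2ccc(F)cc2)nc1-c1ccnc(N2CCCC2)c1`: 80%
Compound 2 `O=C(O)Cc1sc(C2COc3ccccc3O2)nc1-c1ccc(Cl)cc1`: 50%
Compound 3 `O=C(O)Cc1sc(C(c2ccccc2)c2ccc(F)c(F)c2)nc1-c1ccc(F)cc1`: 80%

All three compounds share a core that carries a carboxymethyl group and two aromatic side groups, and all were tested in an in vitro functional assay on HEK285-7 cells for antagonist activity at prostaglandin D2 receptor 2 (Homo sapiens), read by BRET and beta-arrestin recruitment; on this read-out higher numbers stand for larger maximal responses and lower numbers for smaller maximal responses. Compound 1 gives 80%, level with compound 3 at the digits shown and, together with it, the highest of the three numbers; compound 2 sits a good way lower, beyond the usual scatter.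

Compound 4 `Cc1cc(-c2nc(C(c3ccc(F)cc3)c3ccc(F)cc3)sc2CC(=O)O)cnc1N` has not yet been measured. It differs from compound 1 in one place on an aromatic carbon of the shared core: 6-amino-5-methylpyridin-3-yl in place of 2-(pyrrolidin-1-yl)pyridin-4-yl on an aromatic carbon.

Going by the values given here, no pair of measured compounds differing in one place is available, so no measured step guides the expectation. The two compounds with diaryl-methyl groups on the core give the same high maximal response, and compound 4 keeps that feature. A small step, within or just beyond the scatter, is therefore expected in this assay, most likely downward by a modest amount.

Compound 4 is expected to give 75%, with a range from 55% to 95%, which means an expected step of a number 5 percentage points lower from compound 1 to compound 4 (within the scatter).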

Compound 4, largest response reached (reported as efficacy), in percent of the reference or control that the assay uses: 80%
Beside the measured number, compound 4's estimate is 5 percentage points below it, and the stated range covers the measured number.
By their numbers in this assay, from the lowest: compound 2; then compounds 1, 3 and 4 (each within the scatter of the next).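

In this assay, going by these compounds alone, the one step available at this position shows no change at the digits printed from compound 1 to compound 4 (within the scatter) when 6-amino-5-methylpyridin-3-yl takes the place of 2-(pyrrolidin-1-yl)pyridin-4-yl. The maximal response therefore stays within the scatter even though the entering group is smaller, lacks the five-membered non-aromatic ring and carries a hydrogen-bond donor that the leaving group does not. Nothing available here explains why the read-out holds steady across this swap.

The new group differs from the old one in several features at once, so the compounds shown cannot separate the part played by the amino group, the methyl group or the point of attachment on the pyridine. On these data alone, it also remains open whether the response would hold with a morpholine ring in place of the pyrrolidine ring, or with a carboxylic acid on the pyridine.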